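The source may report more compounds than this note shows. Statements on the series, on what has been measured and on what is new or still open speak of the compounds shown alone.

Compound 1 `CS(=O)(=O)Nc1ccc2c(c1)S(=O)(=O)N=C(C1=C(O)C3CCCC3N(Cc3ccc(F)cn3)C1=O)N2` was studied in an in vitro ADME assay on microsomes from liver (Homo sapiens) for metabolic stability; a higher number here means that the compound lasts longer, a lower number that the compound disappears faster. In that setting compound 1 reaches only the limit of the measurement, > 1 h, so no exact number is known for it. Compound 2 `CS(=O)(=O)Nc1ccc2c(c1)S(=O)(=O)N=C(C1=C(O)[C@H]3CCC[C@H]3N(Cc3ccc(F)c(Cl)c3)C1=O)N2` likewise gives only the limit > 1 h in this assay. Compound 3 `CS(=O)(=O)Nc1ccc2c(c1)S(=O)(=O)N=C(C1=C(O)[C@H]3CCC[C@H]3N(Cc3cccc(C(F)(F)F)c3)C1=O)N2` also gives only the limit > 1 h. Among the compounds with values here, the one measured step that changes the group on that ring nitrogen, a step that the two limits leave unreadable from compound 2 to compound 3, therefore cannot be read, because of the limit of > 1 h in this assay, at which 3 of the 3 values shown sit. Compound 4 `CS(=O)(=O)Nc1ccc2c(c1)S(=O)(=O)N=C(C1=C(O)C3CCCC3N(Cc3cccc(F)c3)C1=O)N2` differs from compound 1 by 3-fluorophenyl in place of 5-fluoropyridin-2-yl on a saturated chain carbon bound to an amide-type nitrogen in a ring. With every neighbour sitting at the same limit, compound 4 is expected to sit there too, giving an estimated step that the limit leaves unreadable from compound 1 to compound 4. The estimate for compound 4 is 2 h, between 1 h and 6 h.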

Compound 4, half-life: 0.85 h
Beside the measured number, compound 4's estimate is 2.4-fold (0.37 log units) above it, and the stated range ends above it.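

Among the compounds shown, only compound 4 gives an exact number in this assay, so a group on a saturated chain carbon bound to an amide-type nitrogen in a ring can now bring the half-life under the limit. Putting 3-fluorophenyl in place of 5-fluoropyridin-2-yl gives an at least 1.1-fold lower number from compound 1 to compound 4 (0.07 log units; that floor lies within the scatter). The true size of this step stays unknown, because compound 1 gives only a limit: the limit of > 1 h in this assay, at which 3 of the 4 values shown sit.

Going by these compounds, how an amine or a carboxylic acid at this place would behave in this assay remains open.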